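Working notes: replacing the naphthalen-1-yl group

The source may report more compounds than this note shows. Statements on the series, on what has been measured and on what is new or still open speak of the compounds shown alone.

Compound 1 `O=S(=O)(NCCCNCc1cccc2ccccc12)c1cc(C(F)(F)F)cc(C(F)(F)F)c1` carries naphthalen-1-yl on a saturated chain carbon bound to an amine nitrogen. Within the data shown here, in a functional assay on HPAC cells (Homo sapiens) for inhibition, read by MTT assay, with a stated time of 72 h (a higher number here means a weaker inhibitor of growth, a lower number a stronger inhibitor of growth), compound 1 gives 2400 nM, the lowest of the three numbers measured so far. Compound 2 `COc1ccc(CNCCCNS(=O)(=O)c2cc(C(F)(F)F)cc(C(F)(F)F)c2)cc1OC` gives 3500 nM, and compound 3 `O=S(=O)(NCCCNCc1ccccc1Cl)c1cc(C(F)(F)F)cc(C(F)(F)F)c1` gives 10000 nM. The step of a 1.5-fold higher number from compound 1 to compound 2 (0.16 log units; within the scatter) stays within the scatter, whereas a 4.2-fold higher number from compound 1 to compound 3 (0.62 log units; beyond the scatter) and a 2.9-fold higher number from compound 2 to compound 3 (0.46 log units; beyond the scatter) both go beyond it.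

Compound 4 `COc1ccccc1CNCCCNS(=O)(=O)c1cc(C(F)(F)F)cc(C(F)(F)F)c1` has not yet been measured. It differs from compound 1 as follows: 2-methoxyphenyl in place of naphthalen-1-yl on a saturated chain carbon bound to an amine nitrogen. Among the measured compounds shown here, two measured steps bear on this change. Both a 1.5-fold higher number from compound 1 to compound 2 (0.16 log units; within the scatter) and a 4.2-fold higher number from compound 1 to compound 3 (0.62 log units; beyond the scatter) exchange naphthalen-1-yl for one six-membered aromatic ring of carbon only at the same place; the first stays within the scatter, the second is a modest loss. The expected step is therefore a 2.5-fold higher number from compound 1 to compound 4 (0.40 log units; beyond the scatter), a modest rise, that is, a weaker inhibitor of growth than compound 1. Compound 4 is estimated at 6000 nM, with a range from 2500 nM to 14000 nM.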

Compound 4, concentration for 50% growth inhibition: 2400 nM
Beside the measured number, compound 4's estimate is 2.5-fold (0.40 log units) above it; the measured number lies below the stated range.
By their numbers in this assay, from the lowest: compounds 1, 4 and 2 (each within the scatter of the next); then compound 3.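

With 2-methoxyphenyl in place of naphthalen-1-yl, this assay shows no change at the digits printed from compound 1 to compound 4 (within the scatter), and the comparison with the 3,4-dimethoxyphenyl group gives a 1.5-fold lower number from compound 2 to compound 4 (0.16 log units; within the scatter), so these three groups are not separated at this position. The modest loss seen with 2-chlorophenyl therefore does not go with every single-ring replacement: methoxy in place of chloro on an aromatic carbon gives a 4.2-fold lower number from compound 3 to compound 4 (0.62 log units; beyond the scatter). No measurement available here explains the difference between methoxy and chloro.

The compounds shown leave open how an unsubstituted phenyl, or a 2-methylphenyl or 2-hydroxyphenyl group, would compare with 2-methoxyphenyl. They also leave open whether the same order of groups would hold with a longer chain between the two nitrogens.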